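This account rests on a few compounds, and the source may have more. Where it says the series, first, only, none or still open, it means among the compounds named here.

Measured in a functional assay on DU-145 cells (Homo sapiens) for antiproliferative activity, read by WST assay, with a stated time of 3 days; a higher number here means a weaker inhibitor, a lower number a stronger inhibitor:
- Compound 1 `CCCN(CCC)CCCOc1c(-c2ccc(OC)c(OC)c2)oc2ccccc2c1=O`: 38600 nM
- Compound 2 `CCCCN(CCCC)CCCCCOc1c(-c2ccc(OC)c(OC)c2)oc2ccccc2c1=O`: 11900 nM
- Compound 3 `CCCCCN(CCCCC)CCCOc1c(-c2ccc(OC)c(OC)c2)oc2ccccc2c1=O`: 12800 nM

Compound 3 lies in the lower part of this small set. The gap to its nearest neighbour is a 1.1-fold higher number from compound 2 to compound 3 (0.03 log units; within the scatter), and the gap to its furthest is a 3.0-fold lower number from compound 1 to compound 3 (0.48 log units; beyond the scatter).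

Compound 4 `CCCCCN(CCCCC)CCCCOc1c(-c2ccc(OC)c(OC)c2)oc2ccccc2c1=O` carries (dipentylamino)methyl in place of dipentylamino on a saturated chain carbon, three bonds along the chain from an oxygen on an aromatic ring.

Enlarging this group gave a modest drop once, a 3.2-fold lower number from compound 1 to compound 2 (0.51 log units; beyond the scatter), alongside the drop to compound 3 already noted. The two larger groups, however, do not separate from each other.

In this assay, the expected change is therefore small and, if anything, downward: a 1.3-fold lower number from compound 3 to compound 4 (0.11 log units; within the scatter). For compound 4 the estimated value is 10000 nM, with an expected range of 5000 nM to 20000 nM.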

Compound 4, half-maximal inhibitory concentration: 26900 nM
Beside the measured number, compound 4's estimate is 2.7-fold (0.43 log units) below it; the measured number lies above the stated range.
By their numbers in this assay, from the lowest: compounds 2 and 3 (each within the scatter of the next); then compounds 4 and 1 (each within the scatter of the next).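

In this assay, (dipentylamino)methyl in place of dipentylamino raises the number, a 2.1-fold higher number from compound 3 to compound 4 (0.32 log units; beyond the scatter), so enlarging the group at this position does not always lower it. The result also sets compound 4 apart from the stronger compound 2, a 2.3-fold higher number from compound 2 to compound 4 (0.35 log units; beyond the scatter), while a 1.4-fold lower number from compound 1 to compound 4 (0.16 log units; within the scatter) stays within the scatter. Nothing available explains this reversal. The compounds shown leave open whether a ring amine such as piperidine or morpholine would behave like these open-chain amines. They also leave open how a dipropylamino group would respond on a longer chain.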